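The source may report more compounds than this note shows. Statements on the series, on what has been measured and on what is new or still open speak of the compounds shown alone.

Of the compounds shown here, three sharing one core have been measured in an assay on isolated protein for inhibition of Amine oxidase [flavin-containing] B (Homo sapiens), read by spectrophotometry; on this read-out higher numbers stand for weaker inhibition and lower numbers for stronger inhibition. Compound 1 `C/C(=N\Nc1nc2ccccc2nc1Cc1ccccc1)c1ccccc1` gives 980000 nM in this assay. Compound 2 `C/C(=N\Nc1nc2ccccc2nc1Cc1ccccc1)c1cccs1` gives 850000 nM, and compound 3 `O=[N+]([O-])c1ccc(/C=N/Nc2nc3ccccc3nc2Cc2ccccc2)cc1` gives 960000 nM. All three numbers sit close together: compound 3 stands between the other two, and its gaps to compound 1 and to compound 2 are both within the usual scatter of repeated measurements. The one step among these that changes a single place, from a phenyl ring to a thiophene ring on the carbon that carries the double bond to nitrogen, is a 1.2-fold lower number from compound 1 to compound 2 (0.06 log units; within the scatter).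

Compound 4 `Cc1ccsc1/C=N/Nc1nc2ccccc2nc1Cc1ccccc1` has not yet been measured. It differs from compound 3 in one place: 3-methylthiophen-2-yl in place of 4-nitrophenyl on a carbon with a double bond to nitrogen. This change resembles the step from compound 1 to compound 2, in that a six-membered carbon ring gives way to a five-membered ring holding sulfur on the same carbon; that earlier step stayed within the scatter. For the measured compounds named here, no measured pair shows what removing a nitro group does here. On that basis the expected outcome for compound 4 in this assay is a step of about a 1.1-fold lower number from compound 3 to compound 4 (0.03 log units; within the scatter), which is to say no change beyond the scatter. Compound 4 is therefore estimated at 900000 nM, with a likely range from 400000 nM to 2000000 nM.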

Compound 4, half-maximal inhibitory concentration: 860000 nM
The estimate for compound 4 lay 1.0-fold (0.02 log units) above the measured number; the range from low to high includes it.
By their numbers in this assay, from the lowest: compounds 2, 4, 3 and 1 (each within the scatter of the next).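

In this assay, the 4-nitrophenyl group on the carbon with a double bond to nitrogen can give way to 3-methylthiophen-2-yl, which removes the nitro group and adds a methyl group in a single exchange, and the result is a 1.1-fold lower number from compound 3 to compound 4 (0.05 log units; within the scatter). Two wider exchanges of the whole group on the nitrogen on an aromatic ring also stay within the scatter: a 1.0-fold higher number from compound 2 to compound 4 (0.01 log units; within the scatter), and a 1.1-fold lower number from compound 1 to compound 4 (0.06 log units; within the scatter), so four different groups in this part of the molecule now give numbers that cannot be told apart. No measurement shown here offers an explanation for this flat result.

Going by these compounds, the nitro group and the ring swap changed together from compound 3 to compound 4, so what each contributes alone remains unknown. On these data alone, it also remains open whether any group in this place can move the number beyond the scatter, for example an amine, a carboxylic acid or a longer chain on the ring, or whether a change elsewhere on the shared core would be needed.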